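The source may report more compounds than this note shows. Statements on the series, on what has been measured and on what is new or still open speak of the compounds shown alone.

In an ADME assay on microsomes from liver (Homo sapiens) for metabolic stability, with a stated time of 1 h (on this read-out lower numbers stand for a less stable compound and higher numbers for a more stable compound), compound 1 (`O=[N+]([O-])c1cn2c(n1)OC[C@H](OCC#Cc1ccc(-c3ccc(OC(F)(F)F)cc3)cn1)C2`) gives 68% and compound 2 (`O=[N+]([O-])c1cn2c(n1)OC[C@H](OCc1ccc(-c3ccc(C(F)(F)F)cc3Cl)cc1)C2`) gives 76% as its value, so the two sit within the usual scatter of each other. Compound 3 (`O=[N+]([O-])c1cn2c(n1)OC[C@H](OCC#Cc1ccc(-c3ccc(C(F)(F)F)cc3)cn1)C2`) is not yet measured and differs from compound 1 by trifluoromethyl in place of trifluoromethoxy on an aromatic carbon with trifluoromethyl in place of trifluoromethoxy on an aromatic carbon, para to a large group. For the measured compounds named here, no measured pair differs in one place, so no direct step is available. The estimated step of a number 2 percentage points higher from compound 1 to compound 3 (within the scatter) is expected to stay within the scatter in this assay with no clear direction. For compound 3 the expected value is 70% with an estimated range from 55% to 85% for now.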

Compound 3, percent of the compound remaining in the Homo sapiens assay: 58%
For compound 3 the middle estimate is 12 percentage points above the measured one, within the range that was stated.
By their numbers in the Homo sapiens assay, from the lowest: compounds 3, 1 and 2 (each within the scatter of the next, the first and the last beyond it).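

In the Homo sapiens assay, the series now has its first one-place step, trifluoromethyl in place of trifluoromethoxy on an aromatic carbon, para to a large group, and it reads a number 10 percentage points lower from compound 1 to compound 3 (within the scatter), so this read-out does not separate the two groups. In a physicochemical assay for solubility, read by HPLC, measured as kinetic solubility, with a stated time of 15 min, at pH 1 (on this read-out higher numbers stand for higher solubility and lower numbers for lower solubility), compound 1 gives 3 ug/mL and compound 3 gives 7.6 ug/mL. In the physicochemical assay, the same change does separate them: the measured solubility of compound 1, 3 ug/mL, and of compound 3, 7.6 ug/mL, a 2.5-fold higher number (0.40 log units; beyond the scatter).

For the compounds shown here, only this one pair carries the change, so its reach beyond compound 1 and compound 3 stays open. Going by these compounds, how an amine or a carboxylic acid at this position would read in either assay also stays open.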